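Diethylamino for Dimethylamino on a Longer Chain

A few compounds are considered here, and "the series" means these few. Any claim that something is new, unique, unknown or untested is made for them only; others in the source may bear on it.

Measured compounds:
compound 1 `CN(C)CCCn1c(N)c(-c2nc3cc(Cl)ccc3[nH]2)c2nc(C#N)c(C#N)nc21`: 10700 nM
compound 2 `CCN(CC)CCCn1c(N)c(-c2nc3cc(Cl)ccc3[nH]2)c2nc(C#N)c(C#N)nc21`: 4830 nM
compound 3 `CN(C)CCCCn1c(-c2c(N)n(C)c3nc(C#N)c(C#N)nc23)nc2ccccc21`: 11300 nM

Of the compounds shown here, three have been tested in a functional assay on K562 cells (Homo sapiens) for antiproliferative activity, read by MTT assay, with a stated time of 48 h; on this read-out lower numbers stand for stronger inhibition and higher numbers for weaker inhibition. Compound 1 and compound 2 share one core and differ by a single change, (diethylamino in place of dimethylamino on a saturated chain carbon, three bonds along the chain from an aromatic nitrogen); this change gave a 2.2-fold lower number from compound 1 to compound 2 (0.35 log units; beyond the scatter). Compound 3 carries a different core, and the difference between the two cores is not broken down here. Compound 4 `CCN(CC)CCCCn1c(-c2c(N)n(C)c3nc(C#N)c(C#N)nc23)nc2ccccc21` has not yet been measured; it differs from compound 3 by diethylamino in place of dimethylamino on a saturated chain carbon, four bonds along the chain from an aromatic nitrogen. This is the same kind of change as in the first pair, but not the same: in the first pair the amine sits on a saturated chain carbon three bonds along the chain from an aromatic nitrogen, here it sits four bonds along the chain from an aromatic nitrogen. Because compound 1 to compound 2 gave a 2.2-fold lower number from compound 1 to compound 2 (0.35 log units; beyond the scatter), a step of similar size is expected for compound 4, that is a 2.1-fold lower number from compound 3 to compound 4 (0.31 log units; beyond the scatter), with added uncertainty from the changed core and chain length. Compound 4 is therefore estimated at 5500 nM, likely between 2500 nM and 12000 nM.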

Compound 4, half-maximal inhibitory concentration: 3180 nM
Compound 4: the middle estimate sits 1.7-fold (0.24 log units) above what was measured, and the stated range covers the measured number.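

In this assay, putting diethylamino in place of dimethylamino on the longer chain gave a 3.6-fold lower number from compound 3 to compound 4 (0.55 log units; beyond the scatter), so the number moved the same way as it did in the earlier pair. Seen side by side, the two steps agree in direction, and their sizes cannot be told apart, so in this small set the change carried over from one core to the other: the same change on two cores in this assay, a 2.2-fold lower number (0.35 log units; beyond the scatter) from compound 1 to compound 2 and a 3.6-fold lower number (0.55 log units; beyond the scatter) from compound 3 to compound 4, 1.6-fold (0.21 log units) apart, within the scatter of two such steps. Within the data shown here, this rests on only two pairs, so it does not show that the change would behave the same way on any other core, and it says nothing about why the number falls.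

The compounds shown leave open whether the trend continues with a still larger amine such as dipropylamino, or with a cyclic amine. They also leave open what chain length does by itself, since the two pairs differ in core as well as in chain, and a longer chain carrying the same amine on one core would be needed to separate the two.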